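The source may hold more compounds than are shown below. What is called first, only, known or untested is meant among the compounds shown, and "the series" means these compounds.

Compound 1: `CN(C)CCCOc1ccc(CN2CC[C@H](NC(=O)c3ccccc3)C2)cc1` — 2510 nM
Compound 2: `CC(C)C[C@H](NC(=O)c1cc2ccccc2[nH]1)C(=O)N[C@H]1CCN(Cc2ccc(OCCCN(C)C)cc2)C1` — 501 nM

Both compounds were measured in an assay on HEK293 cells for binding affinity to Urotensin-2 receptor (Homo sapiens), read by radioligand binding; a lower number here means a stronger inhibitor, a higher number a weaker inhibitor. Compound 2 stands at the lower of the two numbers: compound 1 gives 2510 nM, and this gap lies beyond the usual scatter, so compound 2 is the stronger binder of the pair. The two compounds differ in more than one place, so nothing can be said about which part of the structure carries that gap.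

Compound 3, `CC(C)C[C@H](NC(=O)c1ccncc1)C(=O)N[C@H]1CCN(Cc2ccc(OCCCN(C)C)cc2)C1`, keeps the whole frame of compound 2 and changes only the group attached to the carbonyl carbon: pyridin-4-yl in place of 1H-indol-2-yl on a carbonyl carbon. A two-ring group with one hydrogen-bond donor is exchanged for a single six-membered ring with one hydrogen-bond acceptor and no donor. Going by the values given here, no measured pair isolates this exchange, so the expectation rests on the change alone. A moderate loss of affinity, somewhat beyond the scatter, seems the most likely outcome. Compound 3 is therefore expected to give about 1600 nM in this assay, with a likely range from 500 nM to 5000 nM. The estimated step is a 3.2-fold higher number from compound 2 to compound 3 (0.50 log units; beyond the scatter), a weakening of binding.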

Compound 3, inhibition constant: 2000 nM
Beside the measured number, compound 3's estimate is 1.3-fold (0.10 log units) below it; the range from low to high includes it.
By their numbers in this assay, from the lowest: compound 2; then compounds 3 and 1 (each within the scatter of the next).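

Going by these compounds alone, compound 2 and compound 3 differ in one place only, so this is the first measured step that can be tied to a single part of the structure. On the carbonyl carbon, pyridin-4-yl in place of 1H-indol-2-yl gives a 4.0-fold higher number from compound 2 to compound 3 (0.60 log units; beyond the scatter) in this assay, which shows that the group at this position affects binding to the receptor, although only modestly in this one exchange. The exchange changes the ring count, the heavy atoms and the hydrogen-bond donors and acceptors all at once, and no further data show which of these changes matters.

The compounds shown leave open whether the two-ring size or the ring nitrogen of the 1H-indol-2-yl group carries the difference, a question that a benzofuran-2-yl group on the same carbonyl carbon, with oxygen in place of that nitrogen, could help to separate. Also open, as far as these compounds go, is what the rest of the frame contributes, as compound 1 differs from compound 2 and compound 3 in more than one place.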